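Series notes: halogenated aryl variants on an allyl-bearing core

A few compounds are considered here, and "the series" means these few. Any claim that something is new, unique, unknown or untested is made for them only; others in the source may bear on it.

Compound 1 `C=CCn1c(=O)/c(=C\c2cccc(C)c2)[nH]c(=O)/c1=C\c1ccccc1OC` gives 19300 nM in a functional assay on HeLa cells (Homo sapiens) for cytotoxicity, read by CCK-8 assay, with a stated time of 72 h (on this read-out lower numbers stand for stronger inhibition and higher numbers for weaker inhibition), the highest number among the three measured compounds. Its nearest neighbour is compound 3 `C=CCn1c(=O)/c(=C\c2ccccc2Cl)[nH]c(=O)/c1=C\c1ccccc1OC`, which gives 5100 nM in this assay; the furthest is compound 2 `COc1ccccc1/C=c1\c(=O)[nH]/c(=C/c2ccccc2Cl)c(=O)n1C`, which gives 300 nM in this assay.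

Compound 4 `C=CCn1c(=O)/c(=C\c2cc(Br)ccc2F)[nH]c(=O)/c1=C\c1ccccc1OC` differs from compound 1 in one place: 5-bromo-2-fluorophenyl in place of 3-methylphenyl on a double-bonded chain carbon bound to an aromatic carbon.

For the measured compounds named here, the step that bears most directly on this change is the one from compound 1 to compound 3, where a 2-chlorophenyl replaced the 3-methylphenyl at the same place and the number fell: a 3.8-fold lower number from compound 1 to compound 3 (0.58 log units; beyond the scatter). The other measured step, a 17-fold higher number from compound 2 to compound 3 (1.23 log units; beyond the scatter), concerns the saturated chain carbon bound to the aromatic nitrogen, which is unchanged between compound 1 and compound 4, so it does not inform this comparison. Going by the values given here, a halogenated phenyl entering in place of the 3-methylphenyl has so far been accompanied by a modest move to lower numbers; a similar modest step is therefore expected here, with the caveat that only one such step is available.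

For compound 4 the expected value in this assay is 6500 nM, with a range from 2000 nM to 20000 nM, corresponding to an estimated step of a 3.0-fold lower number from compound 1 to compound 4 (0.47 log units; beyond the scatter).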

Compound 4, half-maximal inhibitory concentration: 34600 nM
Estimate against measurement, compound 4: 5.3-fold (0.73 log units) below; the whole stated range lies below it.
By their numbers in this assay, from the lowest: compound 2; then compound 3; then compounds 1 and 4 (each within the scatter of the next).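

In this assay, the step to 5-bromo-2-fluorophenyl in place of 3-methylphenyl reads a 1.8-fold higher number from compound 1 to compound 4 (0.25 log units; within the scatter), so this change cannot be separated from the scatter, whereas the 2-chlorophenyl group of compound 3 gave a step beyond it. The step between the two halogenated groups reads a 6.8-fold higher number from compound 3 to compound 4 (0.83 log units; beyond the scatter), which shows that this position distinguishes one halogenated phenyl from another; compound 4 goes against any reading that a halogen on this phenyl is enough for a lower number, and only compound 3 fits such a reading. No measurement shown here accounts for the difference between these two groups.

From the compounds shown here alone, the bromine and fluorine of compound 4 enter together, so the contribution of each remains open, as does whether the large step seen between compound 2 and compound 3 would recur with 5-bromo-2-fluorophenyl at the same place. Going by these compounds, it also remains open how a phenyl carrying an amine or a carboxylic acid would read at this position on the shared core.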